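Methoxy in place of hydrogen on compound 3

This account rests on a few compounds, and the source may have more. Where it says the series, first, only, none or still open, it means among the compounds named here.

In a functional assay on MCF cells (Homo sapiens) for antiproliferative activity, with a stated time of 72 h (on this read-out lower numbers stand for stronger inhibition and higher numbers for weaker inhibition), compound 3 `COc1cccc(CNc2ncnc3c2ncn3[C@@H]2O[C@H](CO)[C@@H](O)[C@H]2O)c1` gives > 166000 nM as its reading, and that reading is a limit, not a number. Compound 1 `OC[C@H]1O[C@@H](n2cnc3c(NCc4ccccc4F)ncnc32)[C@H](O)[C@@H]1O` gives > 166000 nM as its reading, which is also a limit. Compound 2 `Cc1ccc(CNc2ncnc3c2ncn3[C@@H]2O[C@H](CO)[C@@H](O)[C@H]2O)cc1` gives > 166000 nM as its reading, again a limit. For the measured compounds named here, the series so far offers the limit of > 166000 nM in this assay, at which 3 of the 3 values shown sit, and nothing finer.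

Compound 4 `COc1cccc(CNc2ncnc3c2ncn3[C@@H]2O[C@H](CO)[C@@H](O)[C@H]2O)c1OC` is reached through methoxy in place of hydrogen on an aromatic carbon as the change, which is methoxy in place of hydrogen on an aromatic carbon, or 3-methoxyphenyl to 2,3-dimethoxyphenyl.

The nearest measured changes swap the group on the chain. They are a step that the two limits leave unreadable from compound 1 to compound 3 and a step that the two limits leave unreadable from compound 2 to compound 3 and also a step that the two limits leave unreadable from compound 1 to compound 2 as a third. None of them has a readable size, and none adds a methoxy to a ring that already holds one.

No step beyond the scatter is therefore expected in this assay in either direction, and another limit is the likeliest report. This expectation rests on compound 3 and its limit of > 166000 nM as the nearest reading. The step expected is a number no higher from compound 3 to compound 4 (the limit leaves the size open) by this estimate. For compound 4 the estimate is 166000 nM with an expected range from 80000 nM to 300000 nM around it.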

Compound 4, half-maximal inhibitory concentration: > 166000 nM
Compound 4 gave a limit, no number; the forecaster's own chance of this, stated with the estimate: 85%; the middle value lies on the limit itself.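

In this assay compound 4 gives > 166000 nM, which is a limit and not a number. For the compounds shown here, no step from compound 1, compound 2 or compound 3 to compound 4 can be read, and the series still holds a single reading: the limit of > 166000 nM in this assay, at which 4 of the 4 values shown sit. The compounds shown leave open whether methoxy in place of hydrogen on an aromatic carbon changes the inhibition at all.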